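Replacing 2-hydroxyphenyl with 3-bromophenyl on a shared core

A few compounds are considered here, and "the series" means these few. Any claim that something is new, unique, unknown or untested is made for them only; others in the source may bear on it.

Compound 1 `COc1ccccc1-n1cc(CN2C(=O)C[C@@H]3CC[C@@]2(C)C3(C)C)nn1`: 280 nM
Compound 2 `CC1(C)[C@H]2CC[C@]1(C)N(Cc1cn(-c3ccccc3O)nn1)C(=O)C2`: 410 nM

Both values come from a functional assay on SGC-7901 cells (Homo sapiens) for inhibition, read by MTT assay, with a stated time of 24 h; on this read-out higher numbers stand for weaker inhibition and lower numbers for stronger inhibition. Within the data shown here, compound 2 lies within the usual scatter of compound 1, the only other compound measured, so the two cannot be told apart. Compound 3 `CC1(C)[C@H]2CC[C@]1(C)N(Cc1cn(-c3cccc(Br)c3)nn1)C(=O)C2` keeps the shared core but carries 3-bromophenyl in place of 2-hydroxyphenyl on an aromatic nitrogen. Among the measured compounds shown here, only one measured step bears on this, and only loosely. Hydrogen in place of methyl on an oxygen on an aromatic ring gave a 1.5-fold higher number from compound 1 to compound 2 (0.17 log units; within the scatter). For the measured compounds named here, that step altered the same aromatic ring and stayed within the scatter, but no measured compound carries bromine. No step beyond the scatter is therefore expected in this assay, and no direction can be predicted with confidence. The expected step is a 1.2-fold lower number from compound 2 to compound 3 (0.07 log units; within the scatter). The estimated value for compound 3 is 350 nM, with an expected range from 120 nM to 1000 nM.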

Compound 3, half-maximal inhibitory concentration: 120 nM
Beside the measured number, compound 3's estimate is 2.9-fold (0.46 log units) above it; the range from low to high includes it.
By their numbers in this assay, from the lowest: compound 3; then compounds 1 and 2 (each within the scatter of the next).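

On the aromatic nitrogen of the five-membered ring, the choice of aromatic group does register in this assay: 3-bromophenyl in place of 2-hydroxyphenyl gives a 3.4-fold lower number from compound 2 to compound 3 (0.53 log units; beyond the scatter), and 3-bromophenyl in place of 2-methoxyphenyl gives a 2.3-fold lower number from compound 1 to compound 3 (0.37 log units; beyond the scatter). Both steps lie beyond the scatter, though both are modest, whereas the earlier swap of methyl for hydrogen on the oxygen did not, so this position can respond to a change of group. Nothing measured here says why the number falls.

The change replaces the substituent and shifts its place on the phenyl ring together, so the compounds shown cannot separate the effect of the bromine from the effect of where it sits. As far as these compounds go, it also remains open how a phenyl ring carrying chlorine or an amine in place of the bromine would compare.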